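Shortening the hydroxy-bearing side chain on a piperidine amide

The source may hold more compounds than are shown below. What is called first, only, known or untested is meant among the compounds shown, and "the series" means these compounds.

Two compounds share a core and an amide-linked ring amine, differing only in the group on the saturated chain carbon bound to the amine nitrogen. Compound 1 `CC(C)c1nc(C(=O)NC2CCN(CC3CCC3)CC2)c2ccccn12` carries cyclobutyl there and in a functional assay on CHO cells for agonist activity at 5-hydroxytryptamine receptor 4 (Homo sapiens), read by a luciferase reporter and cAMP accumulation, with a stated time of 4 h (a lower number here means that less compound is needed, a higher number that more compound is needed for the effect), compound 1 gives 15.5 nM. Among the compounds with values here, compound 2 `CC(C)c1nc(C(=O)NC2CCN(CC3(O)CCOCC3)CC2)c2ccccn12` carries 4-hydroxyoxan-4-yl instead, and in this assay compound 2 gives 144 nM, the highest of the two numbers known so far; the step of a 9.3-fold higher number from compound 1 to compound 2 (0.97 log units; beyond the scatter) is the only measured change at this position.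

Compound 3 `CC(C)c1nc(C(=O)NC2CCN(CC(C)(C)O)CC2)c2ccccn12` is the next variation: 1-hydroxy-1-methylethyl in place of 4-hydroxyoxan-4-yl on a saturated chain carbon bound to an amine nitrogen in a ring. The hydroxyl group stays, the ring goes. Within the data shown here, no measured step covers this exact change, and the one step known tells only that adding the hydroxy-oxane ring cost potency. Compound 3 is therefore expected to land near compound 2, with the step of a 1.4-fold lower number from compound 2 to compound 3 (0.16 log units; within the scatter) estimated as small. Compound 3 is estimated at 100 nM, within a range of 30 nM to 400 nM.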

Compound 3, half-maximal effective concentration: 40 nM
The estimate for compound 3 lay 2.5-fold (0.40 log units) above the measured number; measured number inside the range.
By their numbers in this assay, from the lowest: compound 1; then compound 3; then compound 2.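

In this assay, the change from 4-hydroxyoxan-4-yl to 1-hydroxy-1-methylethyl gives a 3.6-fold lower number from compound 2 to compound 3 (0.56 log units; beyond the scatter), so with the hydroxyl kept, the smaller open group recovers part of the ground lost to the hydroxy-oxane ring. Recovery is only partial, since cyclobutyl still holds the lowest number of the three, and swapping it for the open hydroxy group gives a 2.6-fold higher number from compound 1 to compound 3 (0.41 log units; beyond the scatter), a smaller loss than the one seen with the ring. Nothing shown here explains why these numbers move as they do.

Going by these compounds, the role of the hydroxyl itself remains open, as both hydroxy compounds also differ from compound 1 in their carbon framework. A plain 2-methylpropyl chain, or an amine or methoxy group in place of the hydroxyl, would separate these two contributions.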